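This account rests on a few compounds, and the source may have more. Where it says the series, first, only, none or still open, it means among the compounds named here.

Measured in an ADME assay on L1210/0 cells (Mus musculus) for cytotoxicity, with a stated time of 48 h; a lower number here means a stronger inhibitor, a higher number a weaker inhibitor:
- Compound 1 `O=c1[nH]c(=O)n([C@H]2C[C@H](O)[C@@H](CO)O2)cc1CO`: 9180 nM
- Compound 2 `O=C(CI)NCc1cn([C@H]2C[C@H](O)[C@@H](CO)O2)c(=O)[nH]c1=O`: 107000 nM
- Compound 3 `O=c1[nH]c(=O)n([C@H]2C[C@H](O)[C@@H](CO)O2)cc1C1SCCS1`: > 200000 nM

Compound 3 gives no exact number, only a limit of > 200000 nM.

Compound 4 `C=CC#Cc1cn([C@H]2C[C@H](O)[C@@H](CO)O2)c(=O)[nH]c1=O` differs from it on an aromatic carbon: a group of 4 heavy atoms (4 carbon; no ring) in place of a group of 5 heavy atoms (3 carbon, 2 sulfur; one five-membered non-aromatic ring with 2 hetero atoms), on an aromatic carbon. Within the data shown here, three measured steps bear on this site. Both a 12-fold higher number from compound 1 to compound 2 (1.07 log units; beyond the scatter) and an at least 21-fold higher number from compound 1 to compound 3 (1.33 log units; beyond the scatter) are large, while an at least 1.8-fold higher number from compound 2 to compound 3 (0.27 log units; that floor lies within the scatter) has a floor within the scatter. None of these steps introduces a chain like that of compound 4, so they are only a loose guide.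

A measurable value is still expected, in the region of compound 1 at 9180 nM and compound 2 at 107000 nM. The estimated change is an at least 6.6-fold lower number from compound 3 to compound 4 (0.82 log units; beyond the scatter), towards a lower number. For compound 4 the expected value is 30000 nM, with an estimated range of 4000 nM to 150000 nM.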

Compound 4, half-maximal inhibitory concentration: > 200000 nM
Compound 4: only a limit was reported (the forecaster's own chance of this, stated with the estimate: 20%); middle value at least 6.6-fold (0.82 log units) from the limit.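

In this assay compound 4 gives > 200000 nM, a limit of the assay and not a number. An unbranched carbon group with no hydrogen-bond acceptors on this aromatic carbon therefore also gives up the activity of compound 1, with an at least 21-fold higher number from compound 1 to compound 4 (1.33 log units; beyond the scatter), while the comparison with compound 2 shows an at least 1.8-fold higher number from compound 2 to compound 4 (0.27 log units; that floor lies within the scatter). Compound 3 and compound 4 cannot be ranked, and their step cannot be read, because both stop at the same limit: the limit of > 200000 nM in this assay, at which 2 of the 4 values shown sit.

As far as these compounds go, how far either compound lies past that limit stays open. So does whether an amine or a shorter carbon chain at this position would bring the number back towards that of compound 1.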